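Methyl on the sulfonyl aryl ring: working notes on the series

A few compounds are considered here, and "the series" means these few. Any claim that something is new, unique, unknown or untested is made for them only; others in the source may bear on it.

Measured so far:
- compound 1, `O=C(NS(=O)(=O)c1ccccc1)n1ccc2cc(Br)cnc21`: 14.6%
- compound 2, `Cc1ccc(S(=O)(=O)NC(=O)n2ccc3cc(Br)cnc32)cc1`: 82.4%
- compound 3, `CN(C)c1ccnc2c1ccn2C(=O)NS(=O)(=O)c1ccccc1`: 17.6%

All three values come from a functional assay on HT-29 cells (Homo sapiens) for antiproliferative activity, read by MTT assay, with a stated time of 24 h, tested at 10 uM; a lower number here means less inhibition, a higher number more inhibition at the concentration tested (going by the name of the read-out). Compound 1 and compound 2 share one core and differ only by methyl in place of hydrogen on an aromatic carbon; the step this makes is a number 67.8 percentage points higher from compound 1 to compound 2 (beyond the scatter), a large one and well beyond the scatter. Compound 3 carries a different core; the difference between the two cores is not broken down here. Its value lies close to that of compound 1, within the scatter, so no order between compound 1 and compound 3 is claimed; both lie far below compound 2, beyond the scatter.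

Compound 4, `Cc1ccc(S(=O)(=O)NC(=O)n2ccc3c(N(C)C)ccnc32)cc1`, is not yet measured. It differs from compound 3 by methyl in place of hydrogen on an aromatic carbon. Among the measured compounds shown here, this is the same change as the one from compound 1 to compound 2, made at the same kind of place, but on the core of compound 3 rather than the core of compound 1.

In this assay, for the measured compounds named here, the step from compound 3 to compound 4 is expected to be a number 37.4 percentage points higher from compound 3 to compound 4 (beyond the scatter), because a number 67.8 percentage points higher from compound 1 to compound 2 (beyond the scatter) is the only example of this change and it was large; the core is different, so a smaller step is assumed and the range is kept wide. Compound 4 is thus estimated at 55%, with a range from 20% to 85%.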

Compound 4, a percentage reported as inhibition, at one concentration (the size of the read-out at that concentration, not a potency): 21.5%
Compound 4: the middle estimate sits 33.5 percentage points above what was measured; measured number inside the range.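

On the core of compound 3, phenyl to 4-methylphenyl gives a number 3.9 percentage points higher from compound 3 to compound 4 (within the scatter) in this assay, so the large rise seen on the core of compound 1 does not reappear there. The size of this step therefore depends on the core carrying it, and the result on one core cannot be taken as a forecast for the other, with the two steps clearly differing: the same change on two cores in this assay, a number 67.8 percentage points higher (beyond the scatter) from compound 1 to compound 2 and a number 3.9 percentage points higher (within the scatter) from compound 3 to compound 4, 63.9 percentage points apart, beyond the scatter of two such steps This rests on a single pair for each core at one tested concentration, so it shows that the change does not transfer unchanged between these two cores, but not which part of the cores is responsible, why the steps differ, or how the change would behave on any third core.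

From the compounds shown here alone, it remains open whether the rise on the core of compound 1 is specific to methyl or would also appear with a longer chain such as ethyl, or with methoxy or chlorine, in the same place para to the large group. The same groups on the core of compound 3 would show whether any replacement of hydrogen there moves the read-out beyond the scatter.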